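Pyrrolyl to imidazolyl: working notes on the series

A few compounds are considered here, and "the series" means these few. Any claim that something is new, unique, unknown or untested is made for them only; others in the source may bear on it.

Measured in a functional assay on HCT-116 cells (Homo sapiens), read by sulforhodamine B assay, with a stated time of 5 days; a higher number here means a weaker inhibitor of growth, a lower number a stronger inhibitor of growth:
- compound 1 `OC[C@H]1O[C@@H](n2cc(F)c3c(-c4ccco4)ncnc32)[C@H](O)[C@@H]1O` gives 39 nM
- compound 2 `OC[C@H]1O[C@@H](n2cc(F)c3c(-c4cccs4)ncnc32)[C@H](O)[C@@H]1O` gives 9 nM
- compound 3 `OC[C@H]1O[C@@H](n2cc(F)c3c(-c4ccc[nH]4)ncnc32)[C@H](O)[C@@H]1O` gives 450 nM

Compound 3 carries the highest number of the three, well clear of both neighbours. Compound 1 lies closest to it and compound 2 furthest away. The next compound, compound 4 `OC[C@H]1O[C@@H](n2cc(F)c3c(-c4c[nH]cn4)ncnc32)[C@H](O)[C@@H]1O`, is still unmeasured in this assay. It keeps the shared core and changes only the ring on the aromatic carbon: 1H-imidazol-4-yl in place of 1H-pyrrol-2-yl on an aromatic carbon. In words, 1H-imidazol-4-yl stands in place of 1H-pyrrol-2-yl.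

Within the data shown here, two measured steps bear most directly on this change, a 12-fold higher number from compound 1 to compound 3 (1.06 log units; beyond the scatter) and a 50-fold higher number from compound 2 to compound 3 (1.70 log units; beyond the scatter). Both are large, and both show that the number moves strongly with this ring. The third step, a 4.3-fold lower number from compound 1 to compound 2 (0.64 log units; beyond the scatter), is modest but also beyond the scatter. Among the measured compounds shown here, no measured compound has a ring with two hetero atoms, so neither the size nor the direction is secured by the data. A moderate rise is expected, smaller than the two large steps, with a wide margin. The expected step is a 3.3-fold higher number from compound 3 to compound 4 (0.52 log units; beyond the scatter). For compound 4 the estimated value is 1500 nM, with an expected range from 300 nM to 8000 nM.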

Compound 4, concentration for 50% growth inhibition: > 10000 nM
Compound 4: only a limit was reported; the forecaster's own chance of this, stated with the estimate: 15%; middle value at least 6.6-fold (0.82 log units) away from the limit.
By their numbers in this assay, from the lowest: compound 2; then compound 1; then compound 3. At a limit, above all of these: compound 4.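

In this assay compound 4 gives > 10000 nM, which is a limit and not a number: the limit of > 10000 nM in this assay, at which 1 of the 4 values shown sits.

Among the earlier compounds, the ring on the aromatic carbon next to the ring nitrogen held only 1 hetero atom; with 1H-imidazol-4-yl, which holds 2, the series shows an at least 22-fold higher number from compound 3 to compound 4 (1.34 log units; beyond the scatter), and against the other two rings an at least 250-fold higher number from compound 1 to compound 4 (2.40 log units; beyond the scatter) and an at least 1100-fold higher number from compound 2 to compound 4 (3.04 log units; beyond the scatter). The four rings now run in one order by their numbers, from thiophen-2-yl through furan-2-yl and 1H-pyrrol-2-yl to 1H-imidazol-4-yl, and no compound shown goes against it. Compound 3 and compound 4 both carry 1 hydrogen-bond donor on this ring, so that count does not separate them; the entering ring differs from the leaving one by a second ring nitrogen and 1 hydrogen-bond acceptor.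

Still open, going by these compounds, is where a ring with 2 hetero atoms and no hydrogen-bond donor, such as thiazol-2-yl or oxazol-2-yl, would fall in this order, and where a six-membered ring such as pyridin-2-yl would fall. Also open, on these data alone, is whether the same order holds with chlorine or hydrogen in place of the fluorine on the shared core.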